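Carboxy in Place of Trifluoromethyl on a Shared Core

The source may hold more compounds than are shown below. What is called first, only, known or untested is meant among the compounds shown, and "the series" means these compounds.

Compound 1 `Cc1cccc(N/N=C2\CCC(C)n3c2ncc(C(=O)O)c3=O)c1` gives 72.5 umol/kg in a functional assay on the whole organism for inhibition, with Rattus norvegicus as the target; a lower number here means that less compound is needed, a higher number that more compound is needed for the effect. Compound 2 `CC1CC/C(=N\Nc2cccc(C(F)(F)F)c2)c2ncc(C(=O)O)c(=O)n21` returns only > 1000 umol/kg in this assay, which is a limit of the assay rather than a number (the limit of > 1000 umol/kg in this assay, at which 1 of the 2 values shown sits). Going by the values given here, the one measured step, an at least 13-fold higher number from compound 1 to compound 2 (1.13 log units; beyond the scatter), ends at that limit and is known only as a lower bound. Compound 3 `CC1CC/C(=N\Nc2cccc(C(=O)O)c2)c2ncc(C(=O)O)c(=O)n21` differs from compound 2 by carboxy in place of trifluoromethyl on an aromatic carbon. Among the compounds with values here, no measured step covers a carboxy group, so the direction of this step is open. Compound 3 is expected near 500 umol/kg, within 100 umol/kg to 3000 umol/kg. The expected step is an at least 2.0-fold lower number from compound 2 to compound 3 (0.30 log units; that floor lies within the scatter), with a real chance that only a limit is reported again.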

Compound 3, dose for 50% inhibition: > 100 umol/kg
Compound 3: only a limit was reported; the forecaster's own chance of this, stated with the estimate: 50%; the middle value lies beyond the limit too.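

In this assay, compound 3 gives a limit rather than a number: the limit of > 100 umol/kg in this assay, at which 1 of the 3 values shown sits. Compound 2 also gives only a limit, so the step between these two cannot be read, and the change from trifluoromethyl to carboxy on this aromatic carbon has no readable direction. Replacing methyl with carboxy gives an at least 1.3-fold higher number from compound 1 to compound 3 (0.13 log units; that floor lies within the scatter), so carboxy may lie close to methyl here or well beyond it. As far as these compounds go, the true dose for carboxy remains open, and so does how an amine or a methoxy group would read on the same aromatic carbon.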